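A few compounds are considered here, and "the series" means these few. Any claim that something is new, unique, unknown or untested is made for them only; others in the source may bear on it.

Measured so far in an assay on membranes from CHO cells for displacement of a labelled ligand from adenosine receptor A1 (Homo sapiens), read by scintillation counting, with a stated time of 60 min, tested at 1 uM; on this read-out lower numbers stand for less inhibition and higher numbers for more inhibition at the one concentration tested (going by the name of the read-out):
compound 1 `CC1=C(C(=O)OCC(C)C)C(c2ccsc2)NC(=S)N1`: 8%
compound 2 `CC1=C(C(=O)OC(C)(C)C)C(c2ccsc2)NC(=S)N1`: 16%
compound 3 `CC1=C(C(=O)OCC(C)C)C(c2cccs2)NC(=O)N1C`: 9%

Compound 1 and compound 2 share a core and differ by tert-butyl in place of isobutyl on an oxygen next to a carbonyl group; this change gave a number 8 percentage points higher from compound 1 to compound 2 (within the scatter). Compound 3 has another core; the difference between the core of compound 1 and the core of compound 3 is not broken down here. The values of compound 3 and compound 1 sit within the scatter of each other, as do those of compound 3 and compound 2.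

Compound 4 `CC1=C(C(=O)OC(C)(C)C)C(c2cccs2)NC(=O)N1C` has not been measured. It differs from compound 3 by tert-butyl in place of isobutyl on an oxygen next to a carbonyl group, the same change at the same place as between compound 1 and compound 2. Among the measured compounds shown here, the step from compound 3 to compound 4 in this assay is expected to be small, a number 6 percentage points higher from compound 3 to compound 4 (within the scatter), because a number 8 percentage points higher from compound 1 to compound 2 (within the scatter) is the only precedent and rests on one pair. Compound 4 is estimated at 15%, expected between 4% and 27%.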

Compound 4, a percentage reported as inhibition, at one concentration (the size of the read-out at that concentration, not a potency): 18%
For compound 4 the middle estimate is 3 percentage points below the measured one, within the range that was stated.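

In this assay, tert-butyl in place of isobutyl on an oxygen next to a carbonyl group gives a number 9 percentage points higher from compound 3 to compound 4 (within the scatter), and this step reads alike on the two cores: the same change on two cores in this assay, a number 8 percentage points higher (within the scatter) from compound 1 to compound 2 and a number 9 percentage points higher (within the scatter) from compound 3 to compound 4, 1 percentage points apart, within the scatter of two such steps

Within this assay, the change carries from the core of compound 1 to the core of compound 3 with no difference in step size that can be told apart. Both steps lie within the scatter, however, so neither pair establishes an effect of the change on its core, and two pairs say nothing about further cores.

Going by these compounds, what a longer chain or a benzyl group on that oxygen would do in this assay stays open. The difference between the two cores also remains unresolved, as it is not broken down into single changes.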